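Larger Group on the Ring Nitrogen of Compound 3

The source may hold more compounds than are shown below. What is called first, only, known or untested is meant among the compounds shown, and "the series" means these compounds.

Compound 1 `Cc1c2c(n3c1CCCN[C@@H](C)[C@H](C)Nc1cc-3ccc1C(N)=O)CC(C)(C)CC2=O`: 20 nM in a functional assay on NCI-H1975 cells (Homo sapiens) for antiproliferative activity; a higher number here means a weaker inhibitor, a lower number a stronger inhibitor
Compound 2 `Cc1c2c(n3c1CCNC[C@@H](C)[C@H](C)Nc1cc-3ccc1C(N)=O)CC(C)(C)CC2=O`: 27 nM
Compound 3 `Cc1c2c(n3c1CCN(C)C[C@@H](C)[C@H](C)Nc1cc-3ccc1C(N)=O)CC(C)(C)CC2=O`: 27 nM

In this assay compound 3 stands level with compound 2, and together they give the highest of the three numbers; compound 1, with 20 nM, differs from compound 3 only within the scatter. None of the three can be called stronger or weaker than another.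

Compound 4 `Cc1c2c(n3c1CCN(C(=O)[C@@H](O)C(C)C)C[C@@H](C)[C@H](C)Nc1cc-3ccc1C(N)=O)CC(C)(C)CC2=O` has not yet been measured. It differs from compound 3 in one place: (1-hydroxy-2-methylpropyl)carbonyl in place of methyl on an amine nitrogen in a ring. Going by the values given here, the only measured step at this same nitrogen is no change at the digits printed from compound 2 to compound 3 (within the scatter), where a methyl took the place of hydrogen. That step was small in structure and left the number where it was. Among the compounds with values here, the change to compound 4 is much bigger: the entering group brings several more heavy atoms, a hydrogen-bond donor, two acceptors and a defined stereocentre, and no measured pair covers a change of this kind. The data therefore give no direction; the expected step of a 1.3-fold higher number from compound 3 to compound 4 (0.11 log units; within the scatter) is none beyond the scatter, with wide uncertainty.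

Compound 4 is thus estimated at 35 nM, in a range from 10 nM to 130 nM.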

Compound 4, half-maximal inhibitory concentration: 31 nM
Compound 4: middle estimate off by 1.1-fold (0.05 log units), on the high side; the measured number falls inside the stated range.
By their numbers in this assay, from the lowest: compounds 1, 2, 3 and 4 (each within the scatter of the next).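

In this assay the ring nitrogen now has a far larger substituent than before, and the number stays close: (1-hydroxy-2-methylpropyl)carbonyl in place of methyl gives a 1.1-fold higher number from compound 3 to compound 4 (0.06 log units; within the scatter) and the same group in place of hydrogen gives a 1.1-fold higher number from compound 2 to compound 4 (0.06 log units; within the scatter) in this comparison. Until now this nitrogen had only shown the small swap of hydrogen for methyl, whereas the entering group here has 7 heavy atoms, a hydrogen-bond donor, 2 hydrogen-bond acceptors and a defined stereocentre, so in this assay a substituent of this size on this nitrogen can be carried without a step beyond the scatter. Nothing available explains why the number holds, and this one pair says nothing about other assays or properties.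

As far as these compounds go, it remains open whether a chain ending in a carboxylic acid or a primary amine, or a longer carbon chain, would fit on this nitrogen equally well. Also unresolved is whether the hydroxyl-bearing stereocentre matters, as the opposite arrangement at that carbon does not appear among these compounds.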